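Methyl to Nitro on the Sulfonyl Ring: Expected Cytotoxicity

A few compounds are considered here, and "the series" means these few. Any claim that something is new, unique, unknown or untested is made for them only; others in the source may bear on it.

Measured compounds:
Compound 1, `Cc1ccc(S(=O)(=O)N2C/C(=C\c3ccncc3)C(=O)/C(=C/c3ccccc3F)C2)cc1`. In an ADME assay on L02 cells (Homo sapiens) for cytotoxicity, read by MTT assay, with a stated time of 24 h (on this read-out lower numbers stand for stronger inhibition and higher numbers for weaker inhibition), compound 1 gives > 20000 nM, which is a limit of the assay rather than a number.
Compound 2, `O=C1/C(=C/c2ccncc2)CN(S(=O)(=O)c2ccc([N+](=O)[O-])cc2)C/C1=C\c1ccccc1F`. In this assay compound 2 gives 18400 nM.
Compound 3, `Cc1ccc(S(=O)(=O)N2C/C(=C\c3ccncc3)C(=O)/C(=C/c3ccccc3C(F)(F)F)C2)cc1`. In this assay compound 3 gives 12800 nM.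

These three compounds share one core and differ from each other in single groups. Compound 1 and compound 2 differ in one place: nitro in place of methyl on an aromatic carbon. The measured step for this change is an at least 1.0-fold lower number from compound 1 to compound 2 (0.03 log units; that floor lies within the scatter); since the value of compound 1 is a limit (the limit of > 20000 nM in this assay, at which 1 of the 3 values shown sits), only a floor for the step is known. Compound 1 and compound 3 differ in another place: trifluoromethyl in place of fluoro on an aromatic carbon, with a step of an at least 1.5-fold lower number from compound 1 to compound 3 (0.19 log units; that floor lies within the scatter). The numbers for compound 2 and compound 3 lie within the scatter of each other, so nothing separates them.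

Compound 4, `O=C1/C(=C/c2ccncc2)CN(S(=O)(=O)c2ccc([N+](=O)[O-])cc2)C/C1=C\c1ccccc1C(F)(F)F`, is not yet measured. It differs from compound 3 by nitro in place of methyl on an aromatic carbon. The place of this change is the same word for word as the place of the change from compound 1 to compound 2, so it is the same change made on the core of compound 3. The expected step is small, a 1.2-fold lower number from compound 3 to compound 4 (0.07 log units; within the scatter), because an at least 1.0-fold lower number from compound 1 to compound 2 (0.03 log units; that floor lies within the scatter) gives only a floor that lies within the scatter. Compound 3 stands at 12800 nM. Compound 4 is therefore expected to give about 11000 nM in this assay. The estimate for compound 4 most likely falls between 5000 nM and 25000 nM.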

Compound 4, half-maximal inhibitory concentration: 18600 nM
Estimate against measurement, compound 4: 1.7-fold (0.23 log units) below; the range from low to high includes it.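

In this assay, putting 4-nitrophenyl in place of 4-methylphenyl on the core of compound 3 gives a 1.5-fold higher number from compound 3 to compound 4 (0.16 log units; within the scatter), and putting trifluoromethyl in place of fluoro on the core of compound 2 gives a 1.0-fold higher number from compound 2 to compound 4 (0.00 log units; within the scatter), so neither change moves the number beyond the scatter on these cores. For the nitro change, setting this result beside the step on the core of compound 1 shows no measured difference between the two cores, but it does not show that the change carries over in the same way: the same change on two cores in this assay, an at least 1.0-fold lower number (0.03 log units; that floor lies within the scatter) from compound 1 to compound 2 and a 1.5-fold higher number (0.16 log units; within the scatter) from compound 3 to compound 4; the limit leaves it open whether they differ The trifluoromethyl change leaves the same question unanswered: the same change on two cores in this assay, an at least 1.5-fold lower number (0.19 log units; that floor lies within the scatter) from compound 1 to compound 3 and a 1.0-fold higher number (0.00 log units; within the scatter) from compound 2 to compound 4; the limit leaves it open whether they differ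

The compounds shown cover only methyl and nitro at the first place, and only fluoro and trifluoromethyl at the second, so it stays open whether an amine or a carboxylic acid at either place would move the number beyond the scatter. Also open, on these data alone, is how the two changes would compare if the core of compound 1 gave a number, since its value in this assay is a limit and not a number.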